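Swapping One Group on the Weaker Compound

The source may hold more compounds than are shown below. What is called first, only, known or untested is meant among the compounds shown, and "the series" means these compounds.

In a functional assay on DU-145 cells (Homo sapiens) for antiproliferative activity, read by MTT assay, with a stated time of 48 h (on this read-out higher numbers stand for weaker inhibition and lower numbers for stronger inhibition), compound 1 (`COc1cc(-c2nnc(-c3cn4ccccc4n3)o2)cc(OC)c1OC`) gives 4500 nM and compound 2 (`Cc1cc(Br)c2nc(-c3nnc(-c4ccc(Cl)cc4)o3)cn2c1`) gives 46000 nM as the higher of the two numbers, so compound 2 is the weaker inhibitor of this pair. Compound 3 (`Cc1cc(Br)c2nc(-c3nnc(-c4ccc(N(C)C)cc4)o3)cn2c1`) carries dimethylamino in place of chloro on an aromatic carbon, para to a large group (dimethylamino in place of chloro on an aromatic carbon). For the measured compounds named here, no measured pair shows this change, so any forecast remains loose. In this assay a modest move toward stronger inhibition is expected (a 2.3-fold lower number from compound 2 to compound 3 (0.36 log units; beyond the scatter)). Compound 3 is estimated at 20000 nM (range 6000 nM to 60000 nM).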

Compound 3, half-maximal inhibitory concentration: 12800 nM
Compound 3: middle estimate off by 1.6-fold (0.19 log units), on the high side, and the stated range covers the measured number.
By their numbers in this assay, from the lowest: compound 1; then compound 3; then compound 2.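

The first change seen at this aromatic carbon, para to a large group, swaps chloro for dimethylamino and gives a 3.6-fold lower number from compound 2 to compound 3 (0.56 log units; beyond the scatter) in this assay. So what sits at this position matters for inhibition of these cells, and on this core dimethylamino gives stronger inhibition than chloro. For the compounds shown here, with only this one pair, that holds for these two groups alone. As far as these compounds go, whether an unsubstituted amine or a carboxylic acid on the same carbon would move the number further remains open. Nothing measured here says why this step occurs.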